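From bromo to nitro on a shared core

This account rests on a few compounds, and the source may have more. Where it says the series, first, only, none or still open, it means among the compounds named here.

Compound 1 `O=C(CCCCCCN1C(=O)/C(=N\O)c2ccccc21)NO`: 640 nM
Compound 2 `O=C(CCCCCCN1C(=O)/C(=N\O)c2cc(Br)ccc21)NO`: 290 nM

In a functional assay on SW-620 cells (Homo sapiens) for antiproliferative activity, read by sulforhodamine B assay, with a stated time of 48 h (on this read-out higher numbers stand for weaker inhibition and lower numbers for stronger inhibition), compound 2 has the lower of the two numbers at 290 nM, making it the stronger inhibitor of the pair. Compound 3 `O=C(CCCCCCN1C(=O)/C(=N\O)c2cc([N+](=O)[O-])ccc21)NO` carries nitro in place of bromo on an aromatic carbon. Going by the values given here, the only measured step that bears on this change is a 2.2-fold lower number from compound 1 to compound 2 (0.34 log units; beyond the scatter), which is modest and comes from adding bromo in place of hydrogen. Among the compounds with values here, no measured compound carries nitro, so with that step as the only guide, no shift beyond the scatter is expected in this assay. The expected step is a 1.1-fold higher number from compound 2 to compound 3 (0.04 log units; within the scatter). Compound 3 is estimated at 320 nM, with an expected range from 120 nM to 850 nM.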

Compound 3, half-maximal inhibitory concentration: 3390 nM
Estimate against measurement, compound 3: 11-fold (1.03 log units) below; the measured number lies above the stated range.
By their numbers in this assay, from the lowest: compound 2; then compound 1; then compound 3.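

The group at this position can swing the result widely: this assay shows a 12-fold higher number from compound 2 to compound 3 (1.07 log units; beyond the scatter) and a 5.3-fold higher number from compound 1 to compound 3 (0.72 log units; beyond the scatter) on the same core. Nitro therefore moves the number in the opposite direction from bromo, something the earlier step from hydrogen to bromo gave no hint of. Nothing measured here accounts for the difference between the two groups. Going by these compounds, whether an amine or a methoxy group in this place would side with bromo or with nitro stays open. So does whether chloro would behave like bromo.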